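Compound 2 to compound 3: a new group on the carbonyl

The source may hold more compounds than are shown below. What is called first, only, known or untested is meant among the compounds shown, and "the series" means these compounds.

Compound 1 `O=C(Nc1cccc(-n2cc(-c3ccncc3)c(-c3cc(O)cc(Cl)c3)n2)c1)Nc1ccc(Cl)c(Cl)c1` gives -15% in a functional assay on SN12C cells (Homo sapiens) for inhibition, read by sulforhodamine B assay, with a stated time of 48 h, tested at 100 uM; a lower number here means a stronger effect, a higher number a weaker effect of the compound at the concentration tested.
Compound 2 `COc1cc(Cl)cc(-c2nn(-c3cccc(NC(=O)Nc4ccc(Cl)c(Cl)c4)c3)cc2-c2ccncc2)c1` gives 5% in this assay.

Among these two numbers compound 2 stands highest, and the only measured step, a number 20 percentage points higher from compound 1 to compound 2 (beyond the scatter), runs toward it. Both readings indicate little inhibition at the concentration tested.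

Compound 3 `COc1cc(Cl)cc(-c2nn(-c3cccc(NC(=O)c4cccc(C(F)(F)F)c4)c3)cc2-c2ccncc2)c1` differs from compound 2 by 3-(trifluoromethyl)phenyl in place of (3,4-dichlorophenyl)amino on a carbonyl carbon. For the measured compounds named here, the one measured step concerns a methyl in place of hydrogen on an oxygen on an aromatic ring, a place far from the carbonyl, so no measured step bears on this change, and its direction in this assay cannot be read from the data. The expectation therefore rests on compound 2 alone, with a wide range: compound 3 is estimated at 10%, between -20% and 40%, which means an expected step of a number 5 percentage points higher from compound 2 to compound 3 (within the scatter).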

Compound 3, a percentage reported as activity, at one concentration (the size of the read-out at that concentration, not a potency): 52%
The estimate for compound 3 lay 42 percentage points below the measured number; measured number outside the range, above it.
By their numbers in this assay, from the lowest: compound 1; then compound 2; then compound 3.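

The group on the carbonyl carbon matters far more in this assay than the earlier change on the oxygen: a number 47 percentage points higher from compound 2 to compound 3 (beyond the scatter), and a higher number here means a weaker effect. This single swap replaces (3,4-dichlorophenyl)amino, which carries 1 hydrogen-bond donor, with 3-(trifluoromethyl)phenyl, which carries 0, so the urea-type carbonyl of compound 2 becomes the amide-type carbonyl of compound 3. No measurement shown here explains why the effect weakens.

The swap changes both the link to the ring and the groups on that ring, and these two changes cannot be told apart from compound 2 and compound 3 alone. A (3-(trifluoromethyl)phenyl)amino group or a 3,4-dichlorophenyl group on the same carbonyl carbon would show which of the two carries the difference.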